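Swapping the Benzylamine Arm for an Aryl Thioether

A few compounds are considered here, and "the series" means these few. Any claim that something is new, unique, unknown or untested is made for them only; others in the source may bear on it.

Measured so far:
compound 1, `COc1ccc(CNc2nc3cc(N)cc(N)c3nc2-c2ccccc2)cc1OC`, 17000 nM
compound 2, `Nc1cc(N)c2nc(-c3ccccc3)c(NCc3ccc(F)cc3)nc2c1`, 2400 nM

In a functional assay on NCI-H23 cells (Homo sapiens) for inhibition, read by sulforhodamine B assay, with a stated time of 48 h (a lower number here means a stronger inhibitor of growth, a higher number a weaker inhibitor of growth), compound 2 holds the lowest of the two numbers; its nearest neighbour is compound 1, and the gap between them is the step of a 7.1-fold lower number from compound 1 to compound 2 (0.85 log units; beyond the scatter). Compound 3, `Nc1cc(N)c2nc(-c3ccccc3)c(Sc3ccc(Cl)c(Cl)c3)nc2c1`, has not yet been measured. It differs from compound 2 by (3,4-dichlorophenyl)sulfanyl in place of (4-fluorobenzyl)amino on an aromatic carbon. Among the measured compounds shown here, the single measured step, from compound 1 to compound 2, exchanged one ring on the benzyl chain for another while keeping the amino linkage, so it says nothing direct about replacing that linkage with a sulfur-bound aryl ring. For the measured compounds named here, with no measured step bearing on the change, compound 3 is expected to land near compound 2, with a wide range. The step of a 1.7-fold higher number from compound 2 to compound 3 (0.22 log units; within the scatter) is expected to remain modest. In this assay compound 3 is estimated at 4000 nM, between 1000 nM and 20000 nM.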

Compound 3, concentration for 50% growth inhibition: 12600 nM
Compound 3: the middle estimate sits 3.2-fold (0.50 log units) below what was measured; the measured number falls inside the stated range.
By their numbers in this assay, from the lowest: compound 2; then compounds 3 and 1 (each within the scatter of the next).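

In this assay, putting (3,4-dichlorophenyl)sulfanyl in place of (4-fluorobenzyl)amino on this aromatic carbon gives a 5.3-fold higher number from compound 2 to compound 3 (0.72 log units; beyond the scatter), so the number at this position responds to a change in the linkage to the core as well as to a change in the ring of the arm. The step is not a single change: the nitrogen and the chain carbon leave, sulfur enters, and two chlorines stand where the arm held one fluorine, so the compounds cannot assign the shift to any one of these. Nothing measured here explains the shift.

Going by these compounds, it remains open how much of the step belongs to the linkage and how much to the ring substituents. A 3,4-dichlorobenzylamino arm or a 4-fluorophenylsulfanyl arm on the same core would separate the two.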